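This account rests on a few compounds, and the source may have more. Where it says the series, first, only, none or still open, it means among the compounds named here.

Three compounds have been measured in a functional assay on the whole organism (Tail, strain ICR) with Mus musculus as the target, in the tail flick test, with a stated time of 30 min, at a dose of 25 umol/kg by the oral route; on this read-out higher numbers stand for a stronger effect at the one dose given and lower numbers for a weaker effect:

compound 1 `O=C(O)C[C@H](NC(=O)CN(c1nc(Cl)nc2[nH]cnc12)C1CC1)C(=O)O` gives 19.9%;
compound 2 `O=C(CN(c1nc(Cl)nc2[nH]cnc12)C1CC1)N[C@@H](CO)C(=O)O` gives 38.7%;
compound 3 `N=C(N)NCCC[C@H](NC(=O)CN(c1nc(Cl)nc2[nH]cnc12)C1CC1)C(=O)O` gives 45.4%.

Compound 3 holds the highest of the three numbers, although only its step from compound 1 lies beyond the scatter, and compound 2 sits within the scatter of it. The unmeasured compound 4 `CC(C)[C@H](NC(=O)CN(c1nc(Cl)nc2[nH]cnc12)C1CC1)C(=O)O` differs from compound 3 in one place: a group of 3 heavy atoms (3 carbon; no ring) in place of a group of 7 heavy atoms (4 carbon, 3 nitrogen; no ring), on a saturated chain carbon bound to an amide-type nitrogen and a carbonyl carbon. Within the data shown here, two measured steps bear on this, as both swap the group on a saturated chain carbon and arrive at compound 3: a number 25.5 percentage points higher from compound 1 to compound 3 (beyond the scatter), and a number 6.7 percentage points higher from compound 2 to compound 3 (within the scatter). Taking that group away again is therefore expected to lower the number modestly, and the expected step is a number 15.4 percentage points lower from compound 3 to compound 4 (beyond the scatter). Compound 4 is estimated at 30%, within a range from 10% to 55%.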

Compound 4, a percentage reported as activity, at one dose (the size of the read-out at that dose, not a potency): 31.2%
Compound 4: middle estimate off by 1.2 percentage points, on the low side, within the range that was stated.
By their numbers in this assay, from the lowest: compound 1; then compounds 4, 2 and 3 (each within the scatter of the next, the first and the last beyond it).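

Isopropyl carries no nitrogen or oxygen, yet in this assay the swap from carboxymethyl gives a number 11.3 percentage points higher from compound 1 to compound 4 (beyond the scatter) and the swap from hydroxymethyl gives a number 7.5 percentage points lower from compound 2 to compound 4 (within the scatter) at this saturated chain carbon. Only the nitrogen-bearing chain stands clear of isopropyl, as a number 14.2 percentage points lower from compound 3 to compound 4 (beyond the scatter) shows for its replacement. No evidence at hand explains these steps and so the changes stay descriptive. Open, from the compounds shown here alone, is whether a simple amine chain, such as aminobutyl, would match the nitrogen-bearing chain, and whether a benzyl group or a longer hydrocarbon chain would differ from isopropyl.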